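Aryl versus saturated substituent on the shared core: cytotoxicity

A few compounds are considered here, and "the series" means these few. Any claim that something is new, unique, unknown or untested is made for them only; others in the source may bear on it.

Measured so far in an ADME assay on HepG2 cells (Homo sapiens) for cytotoxicity, read by luminescence, CellTiter-Glo and ATP content, with a stated time of 72 h; on this read-out higher numbers stand for an effect only at larger amounts of compound and lower numbers for an effect already at smaller amounts:
compound 1 `CCC(CC)c1ccc2c(NCCCNCc3cccc(OC)c3O)ccnc2c1` gives 410 nM;
compound 2 `COc1cccc(Oc2ccc3c(NCCCNCc4cccc(OC)c4O)ccnc3c2)c1` gives 5300 nM;
compound 3 `COc1cccc(CNCCCNc2ccnc3cc(CC4CCCCC4)ccc23)c1O` gives 970 nM.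

Compound 3 stands second highest of the three numbers. Its nearest neighbour is compound 1, with a 2.4-fold higher number from compound 1 to compound 3 (0.37 log units; beyond the scatter); its furthest is compound 2, with a 5.5-fold lower number from compound 2 to compound 3 (0.74 log units; beyond the scatter). The only aromatic substituent on the core so far, in compound 2, carries the highest number, and a 13-fold higher number from compound 1 to compound 2 (1.11 log units; beyond the scatter) is the largest step in the set.

Compound 4 `COc1cccc(CNCCCNc2ccnc3cc(CCc4ccccc4)ccc23)c1O` differs from compound 3 by benzyl in place of cyclohexyl on a saturated chain carbon bound to an aromatic carbon. An aromatic ring thus enters where compounds 1 and 3 carry only saturated carbon, but through a two-carbon chain rather than the oxygen link of compound 2. The step from compound 2 to compound 3 bears most directly, the step from compound 1 to compound 3 less so. A modest rise in the number is therefore expected for compound 4, short of the step seen with compound 2: a 1.6-fold higher number from compound 3 to compound 4 (0.22 log units; within the scatter). Compound 4 is estimated at 1600 nM, between 600 nM and 4200 nM.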

Compound 4, half-maximal effective concentration: 6800 nM
Compound 4: the middle estimate sits 4.3-fold (0.63 log units) below what was measured; the measured number lies above the stated range.
By their numbers in this assay, from the lowest: compound 1; then compound 3; then compounds 2 and 4 (each within the scatter of the next).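

Exchanging cyclohexyl for benzyl on a saturated chain carbon bound to an aromatic carbon gives a 7.0-fold higher number from compound 3 to compound 4 (0.85 log units; beyond the scatter) in this assay, so an aromatic ring reached through a carbon chain, and not only through the oxygen link of compound 2, goes with a high number. Phenethyl and 3-methoxyphenoxy are not separated (a 1.3-fold higher number from compound 2 to compound 4 (0.11 log units; within the scatter)), while a 17-fold higher number from compound 1 to compound 4 (1.22 log units; beyond the scatter) is now the largest step, and among these four compounds none goes against the split between aromatic and saturated substituents. No measurement at hand gives a reason for this split.

Cyclohexyl and benzyl differ in ring type and in heavy atoms, so the step cannot be assigned to either alone. A cyclohexylethyl group on the same aromatic carbon would separate the two.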